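Cytotoxicity of a fused bicyclic amine series

The source may hold more compounds than are shown below. What is called first, only, known or untested is meant among the compounds shown, and "the series" means these compounds.

Measured so far in an ADME assay on THP-1 cells (Homo sapiens) for cytotoxicity; on this read-out higher numbers stand for lower toxicity in this test and lower numbers for higher toxicity in this test:
Compound 1, `Cn1ccnc1-c1nc2ccccn2c1NC1CCCC1`, gives > 50000 nM, a limit of the test rather than a number.
Compound 2, `COc1ccnc(-c2nc3ccccn3c2Nc2ccc(F)cc2)c1`, gives 4220 nM.
Compound 3, `Fc1ccc(Nc2c(-c3ccc(Cl)cn3)nc3ccccn23)cc1`, gives > 50000 nM, again a limit of the test and not a number.

Among the measured compounds shown here, compound 3 therefore stands at the limit of this assay together with compound 1, while compound 2 is the only member with a measured number; two of the three values sit at the limit of > 50000 nM in this assay, at which 2 of the 3 values shown sit. For the measured compounds named here, the one measured step is an at least 11-fold higher number from compound 2 to compound 3 (1.07 log units; beyond the scatter), so exchanging one pyridyl for another on the shared core moved the read-out out of the measurable range.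

Compound 4, `Cn1ccnc1-c1nc2ccccn2c1Nc1ccc(F)cc1`, is reached from compound 3 by the change (1-methyl-1H-imidazol-2-yl in place of 5-chloropyridin-2-yl on an aromatic carbon). Going by the values given here, no measured step covers this exact exchange. The step from compound 2 to compound 3 shows that the aryl group at this position can shift the read-out by a large amount, and compound 1, which carries the same 1-methyl-1H-imidazol-2-yl group with a different amine, also sits at the limit. Compound 4 is expected to remain at or near the limit, with a step of an at least 1.1-fold lower number from compound 3 to compound 4 (0.04 log units; that floor lies within the scatter) from compound 3 that is not beyond the scatter.

Estimated for compound 4 in this assay: 45000 nM, within 12000 nM to 50000 nM.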

Compound 4, half-maximal cytotoxic concentration: > 50000 nM
Compound 4 was reported as a limit (the forecaster's own chance of this, stated with the estimate: 55%); middle value at least 1.1-fold (0.04 log units) away from the limit.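

In this assay, 1-methyl-1H-imidazol-2-yl in place of 4-methoxypyridin-2-yl on this aromatic carbon gives an at least 11-fold higher number from compound 2 to compound 4 (1.07 log units; beyond the scatter), beyond the scatter. Together with the earlier exchange to 5-chloropyridin-2-yl, this means that two different groups at this position, one a five-membered and one a six-membered aromatic ring, now leave the measurable range when the (4-fluorophenyl)amino group is held constant, and compound 2 remains the one exception among the compounds shown. The steps among compound 1, compound 3 and compound 4 cannot be read, so no order among these three can be given, and the series now offers only one measured number: the limit of > 50000 nM in this assay, at which 3 of the 4 values shown sit.

Going by these compounds, it remains open whether the lower number of compound 2 belongs to the methoxy group or to the pyridine ring that carries it, a question that an unsubstituted pyridin-2-yl group or a pyridin-2-yl group bearing a primary amine at the same place on the ring could address. The exchange of cyclopentyl for 4-fluorophenyl on the nitrogen also stays without a readable size, and a cyclopentyl amine paired with 4-methoxypyridin-2-yl would give that exchange a measured starting point.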